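From phenyl to 1H-pyrrol-2-yl in compound 3

The source may hold more compounds than are shown below. What is called first, only, known or untested is meant among the compounds shown, and "the series" means these compounds.

Measured so far in a functional assay on KB403 cells (Homo sapiens) for cytotoxicity, read by MTT assay, with stated times of 6 h and 48 h (a higher number here means a weaker inhibitor, a lower number a stronger inhibitor), with each compound on its own line
Compound 1 `Cn1c(/C=C/C(=O)c2ccc(O)cc2O)cc(Br)c1Br` gives 12000 nM
Compound 2 `O=C(/C=C/c1cc(Br)c(Br)[nH]1)c1ccccc1O` gives >= 100000 nM as a limit
Compound 3 `Cn1c(-c2cc(-c3ccccc3)no2)cc(Br)c1Br` gives >= 100000 nM as a limit

Compound 3 has no number in this assay and rests on the limit of >= 100000 nM in this assay, at which 2 of the 3 values shown sit, as its only mark. The next step leads to compound 4 `Cn1c(-c2cc(-c3ccc[nH]3)no2)cc(Br)c1Br` with 1H-pyrrol-2-yl in place of phenyl on an aromatic carbon and the rest of compound 3 unchanged. Among the compounds with values here, no two measured compounds differ in just one place, so nothing shows directly how large such a change can be. The expectation therefore starts from compound 3 at >= 100000 nM which is a limit. A modest gain in potency is expected at best, and a second reading at the limit would be no surprise. The expected change is an at least 1.6-fold lower number from compound 3 to compound 4 (0.22 log units; that floor lies within the scatter) as an estimate only. Compound 4 is estimated at 60000 nM with an expected range from 15000 nM to 100000 nM in this assay when it is measured.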

Compound 4, half-maximal inhibitory concentration: 3100 nM
Beside the measured number, compound 4's estimate is 19-fold (1.29 log units) above it, and the stated range ends above it.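

In this assay, the position on the aromatic carbon next to the ring nitrogen, in the five-membered aromatic ring with 1 nitrogen and 1 oxygen, proves highly sensitive to the group it carries. Within the data shown here, exchanging phenyl for 1H-pyrrol-2-yl there gives an at least 32-fold lower number from compound 3 to compound 4 (1.50 log units; beyond the scatter), the first single change whose effect can be read, and it lies beyond the scatter. Compound 3 carries a limit and not a number, so this step is only a floor and its full size remains unknown: the limit of >= 100000 nM in this assay, at which 2 of the 4 values shown sit.

The entering group differs from phenyl in ring size, in its ring nitrogen and in its hydrogen-bond donor, and the compounds shown do not separate these differences. Going by these compounds, how 1-methyl-1H-pyrrol-2-yl or pyridin-2-yl would read at this position remains open.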